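Fluoro for hydrogen in a weakly cytotoxic series

The compounds below may be only part of what the source reports. "The series", "measured", "known", "first", "only" and "open" are said of these compounds alone.

Measured so far in a functional assay on U-937 cells (Homo sapiens) for cytotoxicity, read by MTT assay, with a stated time of 48 h; a higher number here means a weaker inhibitor, a lower number a stronger inhibitor:
Compound 1, `Clc1cccc2sc(Nc3nc4ccccc4s3)nc12`, gives > 50000 nM, which is a limit of the assay.
Compound 2, `Cc1ccc2nc(NC(=S)Nc3ccccc3)sc2c1`, gives > 50000 nM, likewise a limit of the assay.
Compound 3, `Fc1ccc2nc(Nc3nc4c(Cl)cccc4s3)sc2c1`, gives 50000 nM.

Compound 3 differs from compound 1 by fluoro in place of hydrogen on an aromatic carbon. The step of a number no higher from compound 1 to compound 3 (the limit leaves the size open) cannot be sized because of the limit of > 50000 nM in this assay, at which 2 of the 3 values shown sit. The difference between the cores of compound 1 and compound 2 is not broken down here.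

Compound 4, `Cc1ccc2nc(NC(=S)Nc3ccc(F)cc3)sc2c1`, is not yet measured in this assay. It differs from compound 2 by fluoro in place of hydrogen on an aromatic carbon. This is the same kind of change as from compound 1 to compound 3, not the same: in compound 3 the fluoro enters on a ring that is part of a fused or bridged system of two rings, meta to a fused ring and para to a fused ring, whereas in compound 4 it enters para to a large group.

In this assay the step expected from compound 2 to compound 4 is a number no higher from compound 2 to compound 4 (the limit leaves the size open), resting on compound 1 and compound 3, where a number no higher from compound 1 to compound 3 (the limit leaves the size open) left the value at the limit. Compound 4 is therefore expected to give 50000 nM, estimated between 25000 nM and 100000 nM, most probably reported again only as a limit.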

Compound 4, half-maximal inhibitory concentration: > 50000 nM
Compound 4 gave a limit, no number; the forecaster's own chance of this, stated with the estimate: 75%; the middle value lies on the limit itself.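

No new step can be read from compound 2 to compound 4 in this assay, since each gives only a limit and no number: the limit of > 50000 nM in this assay, at which 3 of the 4 values shown sit.
The compounds shown leave open whether phenyl to 4-fluorophenyl on the core of compound 2 changes the value at all, and by how much.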